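This account rests on a few compounds, and the source may have more. Where it says the series, first, only, none or still open, it means among the compounds named here.

Going by the values given here, in a functional assay on SGC-7901 cells (Homo sapiens) for cytotoxicity, read by MTT assay, with a stated time of 48 h (on this read-out lower numbers stand for stronger inhibition and higher numbers for weaker inhibition), compound 3 `CCN(CC)c1ccc2cc(C(=O)c3ccc(N4CCN(S(=O)(=O)c5ccc(C(F)(F)F)cc5)CC4)cc3)oc2c1` gives 170 nM, the lowest number among the values so far; its nearest neighbour is compound 2 `CCN(CC)c1ccc2cc(C(=O)c3ccc(N4CCN(S(=O)(=O)c5ccc([N+](=O)[O-])cc5)CC4)cc3)oc2c1`, which gives 1860 nM. Compound 1 `CCN(CC)c1ccc2cc(C(=O)c3ccc(N4CCN(S(=O)(=O)c5ccc(Br)cc5)CC4)cc3)oc2c1` returns only a limit of the assay, (the limit of > 40000 nM in this assay, at which 1 of the 3 values shown sits), recorded as > 40000 nM. Among the compounds with values here, the measured steps are an at least 21-fold lower number from compound 1 to compound 2 (1.33 log units; beyond the scatter), an at least 230-fold lower number from compound 1 to compound 3 (2.37 log units; beyond the scatter) and an 11-fold lower number from compound 2 to compound 3 (1.04 log units; beyond the scatter), so the single group on the aromatic carbon carries the whole spread of the set. Compound 4 `CCN(CC)c1ccc2cc(C(=O)c3ccc(N4CCN(S(=O)(=O)c5ccc(F)cc5)CC4)cc3)oc2c1` differs from compound 3 by fluoro in place of trifluoromethyl on an aromatic carbon. Within the data shown here, no measured step includes fluoro; both neighbours of trifluoromethyl sit higher, so moving off trifluoromethyl is expected to raise the number, an 8.8-fold higher number from compound 3 to compound 4 (0.95 log units; beyond the scatter). Compound 4 is therefore estimated at 1500 nM, within 300 nM to 8000 nM.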

Compound 4, half-maximal inhibitory concentration: > 40000 nM
Compound 4: only a limit was reported; the forecaster's own chance of this, stated with the estimate: 10%; middle value at least 26-fold (1.42 log units) away from the limit.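

With fluoro on this aromatic carbon, para to a large group, the activity seen with both non-halogen groups is gone, with an at least 230-fold higher number from compound 3 to compound 4 (2.37 log units; beyond the scatter) and an at least 21-fold higher number from compound 2 to compound 4 (1.33 log units; beyond the scatter). Compound 4 returns only a limit, > 40000 nM. The step between compound 1 and compound 4 cannot be read, and both halogen compounds now sit at the same limit: the limit of > 40000 nM in this assay, at which 2 of the 4 values shown sit.

Open, going by these compounds, is how a nitrile, a methyl or an amine on this carbon would read. Also open, on these data alone, is whether any group other than trifluoromethyl reaches the low number of compound 3.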